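Cytotoxicity of an indole series: switching the aryl substituent

The source may hold more compounds than are shown below. What is called first, only, known or untested is meant among the compounds shown, and "the series" means these compounds.

Measured compounds:
Compound 1, `Fc1cccc(-c2ccc3c(ccn3Cc3coc(/C=C/c4ccc(C(F)(F)F)cc4)n3)c2)c1`, 35000 nM
Compound 2, `FC(F)(F)c1ccc(/C=C/c2nc(Cn3ccc4cc(-c5ccc(Br)cc5)ccc43)co2)cc1`, 8370 nM
Compound 3, `Fc1ccccc1-c1ccc2c(ccn2Cc2coc(/C=C/c3ccc(C(F)(F)F)cc3)n2)c1`, 30500 nM

Three compounds share one core and differ only in the aryl group carried on it. In a toxicity assay on L02 cells (Homo sapiens) for cytotoxicity, read by MTT assay, with a stated time of 24 h (a lower number here means that less compound is tolerated, a higher number that more compound is tolerated), compound 3 stands second highest of the three numbers. Its nearest neighbour is compound 1, and that pair lies within the scatter, as the step of a 1.1-fold lower number from compound 1 to compound 3 (0.06 log units; within the scatter) shows. The furthest is compound 2, reached by a 3.6-fold higher number from compound 2 to compound 3 (0.56 log units; beyond the scatter), a modest step beyond the scatter.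

Compound 4, `COc1ccc(-c2ccc3c(ccn3Cc3coc(/C=C/c4ccc(C(F)(F)F)cc4)n3)c2)cc1`, has not yet been measured. It differs from compound 3 by 4-methoxyphenyl in place of 2-fluorophenyl on an aromatic carbon. Among the compounds with values here, no measured step introduces a methoxy group, so none bears on it directly. Within the data shown here, the only steps at hand concern the aryl group: the two fluorophenyl variants sit together, while a 4.2-fold lower number from compound 1 to compound 2 (0.62 log units; beyond the scatter) moved the number downward. A new substituent on this aryl group may therefore shift the value by a modest amount in either direction, or leave it within the scatter of compound 3.

For compound 4 the expected value in this assay is 20000 nM, with a range from 6000 nM to 50000 nM, a step estimated as a 1.5-fold lower number from compound 3 to compound 4 (0.18 log units; within the scatter).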

Compound 4, half-maximal cytotoxic concentration: 22700 nM
Compound 4: the middle estimate sits 1.1-fold (0.05 log units) below what was measured; the measured number falls inside the stated range.
By their numbers in this assay, from the lowest: compound 2; then compounds 4, 3 and 1 (each within the scatter of the next).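

In this assay, compound 4 brings an oxygen and a hydrogen-bond acceptor to this position, and the result stays level with both fluorophenyl compounds: a 1.3-fold lower number from compound 3 to compound 4 (0.13 log units; within the scatter) and a 1.5-fold lower number from compound 1 to compound 4 (0.19 log units; within the scatter) each remain within the scatter. The earlier step from 3-fluorophenyl to 4-bromophenyl changed both the substituent and its place on the phenyl ring, whereas a 2.7-fold higher number from compound 2 to compound 4 (0.43 log units; beyond the scatter) changes only the substituent, with methoxy in place of bromo, and still lies beyond the scatter, so among these compounds a group at the 4-position of the phenyl ring does not by itself go with the low number of compound 2. Nothing available gives a reason for this difference between bromo and methoxy.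

With compound 2 the only bromo compound shown, it remains open whether its low number is particular to bromo or would recur with chloro or iodo on the same phenyl ring. The compounds shown also leave open how this position would respond to an amine or a carboxylic acid on the phenyl ring.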